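Returning from a naphthyl arm toward a phenyl-type arm

The source may hold more compounds than are shown below. What is called first, only, known or untested is meant among the compounds shown, and "the series" means these compounds.

In an ADME assay on MT4 cells (Homo sapiens) for cytotoxicity, read by MTT assay, with a stated time of 5 days (a higher number here means that more compound is tolerated, a lower number that less compound is tolerated), compound 1 `Cc1cc(C#N)cc(C)c1Oc1nc(Nc2ccc(C#N)cc2)ncc1-c1ccccc1` gives 31800 nM. Compound 2 `Cc1cc(C#N)cc(C)c1Oc1nc(Nc2ccc(C#N)cc2)ncc1-c1cccc2ccccc12` gives only a limit of this assay, > 267000 nM. The step of an at least 8.3-fold higher number from compound 1 to compound 2 (0.92 log units; beyond the scatter) ends at the limit (the limit of > 267000 nM in this assay, at which 1 of the 2 values shown sits), so compound 2 stands at the upper edge of the numbers shown, with no number of its own. Compound 3 `Cc1cc(C#N)cc(C)c1Oc1nc(Nc2ccc(C#N)cc2)ncc1-c1ccc(N)cc1` differs from compound 2 in that (4-aminophenyl in place of naphthalen-1-yl on an aromatic carbon). Among the measured compounds shown here, this largely undoes the one measured step, so a fall back toward compound 1 is expected. Compound 3 is thus expected to show a step of an at least 5.3-fold lower number from compound 2 to compound 3 (0.72 log units; beyond the scatter). Compound 3 is estimated at 50000 nM, within 15000 nM to 267000 nM.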

Compound 3, half-maximal cytotoxic concentration: 310 nM
For compound 3 the middle estimate is 160-fold (2.21 log units) above the measured one; the whole stated range lies above it.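

The amino group turns out to matter more at this position than the change of arm size did: on the phenyl arm, amino in place of hydrogen gives a 100-fold lower number from compound 1 to compound 3 (2.01 log units; beyond the scatter). Replacing naphthalen-1-yl with 4-aminophenyl gives an at least 860-fold lower number from compound 2 to compound 3 (2.93 log units; beyond the scatter), so the same position can shift this assay strongly in either direction. Compound 2 has only a limit, not a number: the limit of > 267000 nM in this assay, at which 1 of the 3 values shown sits.

The compounds shown leave open whether this fall is specific to the amino group. A hydroxyl or methyl group on the same phenyl arm would test that.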